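The source may hold more compounds than are shown below. What is called first, only, known or untested is meant among the compounds shown, and "the series" means these compounds.

The measured compounds so far:

Compound 1, `CN(C(=O)NC(=O)c1ccc(C(F)(F)F)cc1)c1nc(C(F)(F)F)c(C(=O)N/N=C/c2ccc(C(F)(F)F)cc2)s1`, in a functional assay on HepG2 cells (Homo sapiens) for inhibition, read by MTT assay, with a stated time of 72 h (a higher number here means a weaker inhibitor, a lower number a stronger inhibitor), reaches only the assay limit of > 100 ug/mL; that entry is a limit, not a number.

Compound 2, `CN(C(=O)NC(=O)c1ccc(C(F)(F)F)cc1)c1nc(C(F)(F)F)c(C(=O)N/N=C/c2cccc(C(F)(F)F)c2)s1`, in this assay gives 7.95 ug/mL.

Compound 3, `CN(C(=O)NC(=O)c1c(Cl)cccc1Cl)c1nc(C(F)(F)F)c(C(=O)N/N=C/c2ccccc2C(F)(F)F)s1`, in this assay gives 8.95 ug/mL.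

Compound 3 and compound 2 thus give numbers that sit within the usual scatter of each other, and only compound 1 stands apart from them with its limit (the limit of > 100 ug/mL in this assay, at which 1 of the 3 values shown sits). Among the compounds with values here, the one measured step, an at least 12-fold lower number from compound 1 to compound 2 (1.09 log units; beyond the scatter), concerns the carbon with a double bond to nitrogen, on the hydrazone side of the shared core. Compound 2 and compound 3 differ from each other in two places at once, so their two values show only that both lie close together.

Compound 4, `CN(C(=O)NC(=O)c1c(F)cccc1F)c1nc(C(F)(F)F)c(C(=O)N/N=C/c2ccccc2C(F)(F)F)s1`, differs from compound 3 in one place: 2,6-difluorophenyl in place of 2,6-dichlorophenyl on a carbonyl carbon. Within the data shown here, no measured step touches this carbonyl side of the molecule, so the only guide is that the two numbers found so far lie close together. The step from compound 3 to compound 4 is therefore expected to stay within the scatter, a 1.0-fold higher number from compound 3 to compound 4 (0.00 log units; within the scatter), and compound 4 is estimated at 9 ug/mL in this assay, with a range from 3 ug/mL to 30 ug/mL.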

Compound 4, half-maximal inhibitory concentration: 26.1 ug/mL
The estimate for compound 4 lay 2.9-fold (0.46 log units) below the measured number; low and high end bracket the measured number.
By their numbers in this assay, from the lowest: compounds 2 and 3 (each within the scatter of the next); then compound 4. At a limit, above all of these: compound 1.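

In this assay, within the data shown here, 2,6-difluorophenyl in place of 2,6-dichlorophenyl on a carbonyl carbon gives a 2.9-fold higher number from compound 3 to compound 4 (0.46 log units; beyond the scatter), the first measured step on this side of the molecule. The carbonyl side can therefore shift the number beyond the usual scatter, although the step is modest and the two groups have the same count of heavy atoms and the same carbon ring, differing only in carrying fluorine instead of chlorine. Nothing measured here gives a reason for this difference between the two groups.

The compounds shown leave open how this position responds to other kinds of group on the carbonyl carbon, such as an unsubstituted phenyl, a phenyl carrying an amine or a carboxylic acid, or a longer alkyl chain in place of the ring. Among these compounds, they also leave open whether the same exchange of chlorine for fluorine would shift the number in the same direction when the trifluoromethylphenyl on the hydrazone side is the one carried by compound 2 rather than the one shared by compound 3 and compound 4.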